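The compounds below may be only part of what the source reports. "The series", "measured", "known", "first", "only" and "open" are said of these compounds alone.

Compound 3 `Oc1ccc(-c2cc(-c3ccc(OC(F)(F)F)cc3)cc(-c3cccc(O)c3)n2)cc1` is one of three compounds tested in a functional assay on DU-145 cells (Homo sapiens) for inhibition; a lower number here means a stronger inhibitor, a higher number a weaker inhibitor. Among the compounds with values here, compound 3 gives 18100 nM, the only value reported as a number. Compound 1 `Oc1ccc(-c2cc(-c3ccc(C(F)(F)F)cc3)cc(-c3ccc(O)cc3)n2)cc1` reaches only the limit of the assay, > 50000 nM. Compound 2 `Oc1ccc(-c2cc(-c3ccc(OC(F)(F)F)cc3)cc(-c3ccccc3O)n2)cc1` likewise reaches only the limit of the assay, > 50000 nM. Within the data shown here, the one measured step that yields a size is an at least 2.7-fold lower number from compound 2 to compound 3 (0.44 log units; beyond the scatter), and it runs into the limit, as the limit of > 50000 nM in this assay, at which 2 of the 3 values shown sit, shows.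

Compound 4 `Oc1ccc(-c2cc(-c3ccc(OC(F)(F)F)cc3)cc(-c3ccc(O)cc3)n2)cc1` has not yet been measured. Compound 4 differs from compound 3 in one place: 4-hydroxyphenyl in place of 3-hydroxyphenyl on an aromatic carbon. The hydroxyl thus moves again around the outer ring, this time to the position already held by the other 4-hydroxyphenyl group on the shared core.

Among the measured compounds shown here, no measured step compares a 3-hydroxyphenyl with a 4-hydroxyphenyl group, so the earlier step gives only an indirect guide. Compound 1 carries two 4-hydroxyphenyl groups, with a trifluoromethyl rather than a trifluoromethoxy group on the third ring, and stays at the limit. Compound 4 is therefore expected to be weaker than compound 3 in this assay, with a step of a 2.5-fold higher number from compound 3 to compound 4 (0.40 log units; beyond the scatter), most likely ending at the limit. Compound 4 is estimated at 45000 nM, within 15000 nM to 150000 nM.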

Compound 4, half-maximal inhibitory concentration: 5390 nM
Estimate against measurement, compound 4: 8.3-fold (0.92 log units) above; measured number below the stated range.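

In this assay, within the data shown here, the earlier compounds showed only that a 3-hydroxyphenyl group on this aromatic carbon next to the ring nitrogen does better than a 2-hydroxyphenyl group; the new result extends that trend, with a 3.4-fold lower number from compound 3 to compound 4 (0.53 log units; beyond the scatter) for the 4-hydroxyphenyl group and an at least 9.2-fold lower number from compound 2 to compound 4 (0.96 log units; beyond the scatter) across the whole move of the hydroxyl. So, among these three compounds, which share the rest of their structure, where the hydroxyl sits on this ring clearly matters, and the 4-hydroxyphenyl group gives the strongest inhibitor. Compound 1 has the same two 4-hydroxyphenyl groups, so this group alone does not ensure activity: trifluoromethoxy in place of trifluoromethyl on the third ring gives an at least 9.2-fold lower number from compound 1 to compound 4 (0.96 log units; beyond the scatter), and this step and the one from compound 2 are minimum sizes, set by the assay's ceiling: the limit of > 50000 nM in this assay, at which 2 of the 4 values shown sit.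

The compounds shown leave open whether the hydroxyl itself is needed at this position, since none replaces it with a methoxy group or an amine. They also leave open whether the same order of hydroxyl positions would hold with trifluoromethyl on the third ring, and how much further a longer chain there might shift the number.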